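The source may hold more compounds than are shown below. What is called first, only, known or untested is meant among the compounds shown, and "the series" means these compounds.

Measured so far:
compound 1 `C=CC1=C(C(=O)NCCC)C(c2ccc(Cl)c(Cl)c2)OC1` — > 100000 nM
compound 2 `C=CC1=C(C(=O)NCC(C)C)C(c2ccc(Cl)c(Cl)c2)OC1` — 60100 nM
compound 3 `C=CC1=C(C(=O)NCCC)C(c2ccc(OC)cc2)OC1` — 14000 nM

In a functional assay on HeLa cells (Homo sapiens) for cytotoxicity, read by MTT assay, with a stated time of 24 h (a higher number here means a weaker inhibitor, a lower number a stronger inhibitor), compound 1 gives only a limit, > 100000 nM; this is the limit of > 100000 nM in this assay, at which 1 of the 3 values shown sits. Compound 2 differs from compound 1 by methyl in place of hydrogen on a saturated chain carbon bound to two saturated chain carbons, and this change made an at least 1.6-fold lower number from compound 1 to compound 2 (0.22 log units; that floor lies within the scatter). Compound 3 carries a different core; the difference between the two cores is not broken down here. In this assay compound 2 gives 60100 nM, and compound 3 gives 14000 nM, the lower of the two numbers and the lowest number among the three compounds.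

Compound 4 `C=CC1=C(C(=O)NCC(C)C)C(c2ccc(OC)cc2)OC1` is not yet measured. It differs from compound 3 by methyl in place of hydrogen on a saturated chain carbon bound to two saturated chain carbons, the same change as from compound 1 to compound 2. Because the earlier step is known only as an at least 1.6-fold lower number from compound 1 to compound 2 (0.22 log units; that floor lies within the scatter), a floor that lies within the scatter, the expectation for compound 4 is a change close to no change, a 1.4-fold lower number from compound 3 to compound 4 (0.15 log units; within the scatter). Compound 4 is estimated at 10000 nM, with a range of 3500 nM to 35000 nM.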

Compound 4, half-maximal inhibitory concentration: > 100000 nM
Compound 4: a limit, no number; the forecaster's own chance of this, stated with the estimate: 5%; middle value at least 10-fold (1.00 log units) away from the limit.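

Methyl in place of hydrogen on a saturated chain carbon bound to two saturated chain carbons, which turns propyl into isobutyl, gives an at least 7.1-fold higher number from compound 3 to compound 4 (0.85 log units; beyond the scatter) in this assay, and this change does not carry from one core to the other: the same change on two cores in this assay, an at least 1.6-fold lower number (0.22 log units; that floor lies within the scatter) from compound 1 to compound 2 and an at least 7.1-fold higher number (0.85 log units; beyond the scatter) from compound 3 to compound 4, at least 11-fold (1.07 log units) apart, beyond the scatter of two such steps

Compound 4 gives > 100000 nM, which is a limit and not a number, and the series reaches this limit more than once: the limit of > 100000 nM in this assay, at which 2 of the 4 values shown sit.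

The two pairs show that the outcome of this one change depends on the core, but they do not show which part of the core decides it, and neither step has a true size, as each rests on a limit.

The compounds shown leave open how chains other than propyl and isobutyl behave on either core, such as a longer chain like pentyl or a chain ending in an amine or a carboxylic acid. They also leave open whether a third core, for instance one carrying a fluorine on the aromatic ring, would follow compound 1 and compound 2 or compound 3 and compound 4.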